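Methoxy in place of hydrogen: working notes on compound 3

This account rests on a few compounds, and the source may have more. Where it says the series, first, only, none or still open, it means among the compounds named here.

Measured so far in a functional assay on BT-549 cells (Homo sapiens) for inhibition, read by sulforhodamine B assay, with a stated time of 48 h; a lower number here means that less compound is tolerated, a higher number that more compound is tolerated:
compound 1, `COc1ccc(-c2cc(/C=C/C(=O)c3ccc(N)cc3)[nH]n2)cc1`: 36300 nM
compound 2, `COc1cc(-c2cc(/C=C/C(=O)c3ccc(F)c(F)c3)[nH]n2)cc(OC)c1OC`: 79500 nM

Compound 1 stands at the lower of the two numbers in this assay; compound 2 sits at a higher number, and that gap is beyond the scatter. Among the compounds with values here, the two compounds differ in several places at once, so no single step between them can be read from these values.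

Compound 3, `COc1ccc(-c2cc(/C=C/C(=O)c3ccc(N)cc3)[nH]n2)cc1OC`, is not yet measured. It differs from compound 1 in one place: methoxy in place of hydrogen on an aromatic carbon. Within the data shown here, no measured pair in this set isolates this change, so the expectation for compound 3 rests on the value of compound 1 alone, with compound 2 as the only other point in this assay.

The expected step from compound 1 to compound 3 in this assay is a 1.1-fold higher number from compound 1 to compound 3 (0.04 log units; within the scatter), small and within the scatter, with no clear direction. Compound 3 is therefore estimated at 40000 nM in this assay, with a range from 15000 nM to 100000 nM.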

Compound 3, concentration lethal to 50% of the cells: 5770 nM
For compound 3 the middle estimate is 6.9-fold (0.84 log units) above the measured one; the whole stated range lies above it.
By their numbers in this assay, from the lowest: compound 3; then compound 1; then compound 2.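

In this assay a methoxy in place of hydrogen, on the aromatic carbon ortho to a methoxy group and meta to a large group, gives a 6.3-fold lower number from compound 1 to compound 3 (0.80 log units; beyond the scatter) and so shows that this position is not indifferent to substitution. Within the data shown here, this is the first change that can be read on its own, since the two earlier compounds differ in several places at once, and it shows that a single added methoxy on the core of compound 1 can move the number beyond the scatter. No measurement here accounts for the step, so the result stands as an observation on one pair.

The compounds shown do not tell whether a hydroxyl, a fluorine or a longer ether chain such as ethoxy on the same carbon would give a step of similar size, or whether the methoxy itself is needed. They also leave open whether the step carries over to a background other than that of compound 1, such as one bearing the two fluorine atoms of compound 2.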